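Methyl for Bromo at the Aryl Ring: an Expected Outcome

The compounds below may be only part of what the source reports. "The series", "measured", "known", "first", "only" and "open" are said of these compounds alone.

Measured compounds:
compound 1, `O=C(CSc1ncccn1)N/N=c1/scc(-c2ccc(Br)cc2)n1-c1ccccc1`, gives 69%
compound 2, `Cn1cnnc1SCC(=O)N/N=c1/scc(-c2ccc(C#N)cc2)n1-c1ccccc1`, gives 58.8%
compound 3, `COc1ccc(-c2cs/c(=N/NC(=O)CSc3nnc(C)s3)n2-c2ccccc2)cc1`, gives 31.5%

Of the compounds shown here, three sharing one core have been tested in a functional assay on C6 cells (Rattus norvegicus) for cytotoxicity, read by MTT assay, with a stated time of 24 h, tested at 50 ug/mL; a higher number here means a weaker effect of the compound at the concentration tested, a lower number a stronger effect. Compound 1 stands highest of the three numbers; compound 2 lies closest to it, a gap beyond the scatter, and compound 3 lies furthest from it, also beyond the scatter. Among the measured compounds shown here, no pair of these three differs in only one place, so none of the gaps can be tied to a single structural change.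

Compound 4, `Cc1ccc(-c2cs/c(=N/NC(=O)CSc3ncccn3)n2-c2ccccc2)cc1`, has not yet been measured in this assay. It differs from compound 1 in one place: methyl in place of bromo on an aromatic carbon. Cut one bond further out, the change reads 4-bromophenyl to 4-methylphenyl. For the measured compounds named here, no measured pair shows what such an exchange does here, so nothing in these data supports a step in either direction beyond the scatter. The step from compound 1 to compound 4 in this assay is expected to be a number 4 percentage points lower from compound 1 to compound 4 (within the scatter), within the scatter. Compound 4 is therefore expected to give about 65%, between 45% and 85%.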

Compound 4, a percentage reported as activity, at one concentration (the size of the read-out at that concentration, not a potency): 64.4%
For compound 4 the middle estimate is 0.6 percentage points above the measured one, within the range that was stated.
By their numbers in this assay, from the lowest: compound 3; then compounds 2, 4 and 1 (each within the scatter of the next, the first and the last beyond it).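

Among the compounds shown here, the exchange of bromo for methyl gives the first comparison in this set that differs in only one place: in this assay, the change on an aromatic carbon, para to a large group, is a number 4.6 percentage points lower from compound 1 to compound 4 (within the scatter). At the concentration tested, 4-bromophenyl and 4-methylphenyl therefore cannot be told apart at this position, at least with the rest of compound 1 in place. Nothing measured here bears on the reason for this result.

As far as these compounds go, whether an amine or a carboxylic acid at this position would give a step beyond the scatter remains open, as does whether the same exchange would read alike with a different group on the sulfur side chain. The gaps involving compound 2 and compound 3 still cannot be read, since each of these compounds differs from the others in more than one place.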